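This account rests on a few compounds, and the source may have more. Where it says the series, first, only, none or still open, it means among the compounds named here.

Compound 1 (`COc1ccc(C=C(C(=O)/C=C/c2ccc(O)c(OC)c2)C(=O)/C=C/c2ccc(O)c(OC)c2)c(OC)c1`), compound 2 (`COc1cc(/C=C/C(=O)C(=Cc2cccc(F)c2)C(=O)/C=C/c2ccc(O)c(OC)c2)ccc1O`) and compound 3 (`CCc1ccc(C=C(C(=O)/C=C/c2ccc(O)c(OC)c2)C(=O)/C=C/c2ccc(O)c(OC)c2)cc1`) share one core and differ only in the aromatic group on a double-bonded chain carbon bound to a double-bonded chain carbon. In a functional assay on A549 cells (Homo sapiens) for inhibition, read by sulforhodamine B assay, with a stated time of 48 h (a higher number here means a weaker inhibitor of growth, a lower number a stronger inhibitor of growth), compound 1 gives 690 nM, compound 2 gives 360 nM and compound 3 gives 550 nM. Compound 3 therefore stands within the scatter of both others, with a 1.3-fold lower number from compound 1 to compound 3 (0.10 log units; within the scatter) and a 1.5-fold higher number from compound 2 to compound 3 (0.18 log units; within the scatter). The remaining step, a 1.9-fold lower number from compound 1 to compound 2 (0.28 log units; within the scatter), is also within the scatter.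

Compound 4 (`COc1cc(/C=C/C(=O)C(=Cc2cccc(OC)c2OC)C(=O)/C=C/c2ccc(O)c(OC)c2)ccc1O`) has not yet been measured. It differs from compound 3 by one change at the same place: 2,3-dimethoxyphenyl in place of 4-ethylphenyl on a double-bonded chain carbon bound to a double-bonded chain carbon. The three groups tested there have so far produced no step beyond the scatter, and compound 1, at 690 nM, also carries a dimethoxyphenyl group. No step beyond the scatter is therefore expected in this assay, and the estimated change is a 1.1-fold higher number from compound 3 to compound 4 (0.04 log units; within the scatter). For compound 4 the expected value is 600 nM, with an estimated range from 300 nM to 1200 nM.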

Compound 4, concentration for 50% growth inhibition: 420 nM
Compound 4: middle estimate off by 1.4-fold (0.15 log units), on the high side; measured number inside the range.
By their numbers in this assay, from the lowest: compounds 2, 4, 3 and 1 (each within the scatter of the next).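

In this assay, exchanging 4-ethylphenyl for 2,3-dimethoxyphenyl, which brings 2 oxygen atoms and 2 hydrogen-bond acceptors to this place, gives only a 1.3-fold lower number from compound 3 to compound 4 (0.12 log units; within the scatter) and so adds acceptors without a step beyond the scatter. The two dimethoxyphenyl groups can now be compared directly, and a 1.6-fold lower number from compound 1 to compound 4 (0.22 log units; within the scatter) shows no readable effect of where the methoxy groups sit, while the comparison with the fluorinated group, a 1.2-fold higher number from compound 2 to compound 4 (0.07 log units; within the scatter), also stays small. No available measurement explains these numbers.

All four groups are substituted phenyl rings, so the compounds shown leave open what an amine or a carboxylic acid on the ring would do. They also leave open whether a step beyond the scatter would follow if a short alkyl chain replaced the ring altogether.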